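Removing the Hydroxymethyl from the Dioxolane of Compound 3

The compounds below may be only part of what the source reports. "The series", "measured", "known", "first", "only" and "open" are said of these compounds alone.

Compound 3 `CC1(C)O[C@@H](CO)[C@H](Cn2cc(Cn3c4c(c5ccccc53)C(=O)c3c[n+]([O-])c5ccccc5c3C4=O)nn2)O1` gives 680 nM in a functional assay on MDA-MB-231 cells (Homo sapiens) for cytotoxicity, read by MTT assay, with a stated time of 72 h; a higher number here means a weaker inhibitor, a lower number a stronger inhibitor. Among the three numbers so far it stands at the upper edge of a spread that the scatter covers entirely: compound 1 `O=C1c2c[n+]([O-])c3ccccc3c2C(=O)c2c1c1ccccc1n2Cc1cn([C@H]2C[C@H](O)[C@@H](CO)O2)nn1` gives 580 nM and compound 2 `O=C1c2c[n+]([O-])c3ccccc3c2C(=O)c2c1c1ccccc1n2Cc1cn(C[C@@H](O)CO)nn1` gives 670 nM, so the steps of a 1.2-fold higher number from compound 1 to compound 3 (0.07 log units; within the scatter) and a 1.0-fold higher number from compound 2 to compound 3 (0.01 log units; within the scatter) both lie within the scatter, as does a 1.2-fold higher number from compound 1 to compound 2 (0.06 log units; within the scatter). Compound 4 `CC1(C)OCC(Cn2cc(Cn3c4c(c5ccccc53)C(=O)c3c[n+]([O-])c5ccccc5c3C4=O)nn2)O1` has not yet been measured in this assay. Its change from compound 3 is 2,2-dimethyl-1,3-dioxolan-4-yl in place of 5-(hydroxymethyl)-2,2-dimethyl-1,3-dioxolan-4-yl on a saturated chain carbon bound to an aromatic nitrogen. Going by the values given here, the steps that bear on it each rework the group on the saturated chain carbon bound to an aromatic nitrogen, or the group on the aromatic nitrogen itself, and none of them moved the number beyond the scatter. The present change removes only the hydroxymethyl from that group, so no step beyond the scatter is expected: a 1.0-fold higher number from compound 3 to compound 4 (0.01 log units; within the scatter). Compound 4 is therefore estimated at 700 nM, with a range from 350 nM to 1400 nM.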

Compound 4, half-maximal inhibitory concentration: 230 nM
The estimate for compound 4 lay 3.0-fold (0.48 log units) above the measured number; measured number outside the range, below it.
By their numbers in this assay, from the lowest: compound 4; then compounds 1, 2 and 3 (each within the scatter of the next).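

In this assay, the group on a saturated chain carbon bound to an aromatic nitrogen proved able to shift the number: removing the hydroxymethyl gave a 3.0-fold lower number from compound 3 to compound 4 (0.47 log units; beyond the scatter), whereas the earlier reworkings of this part stayed within the scatter. The other two comparisons agree, with a 2.9-fold lower number from compound 2 to compound 4 (0.46 log units; beyond the scatter) and a 2.5-fold lower number from compound 1 to compound 4 (0.40 log units; beyond the scatter), so compound 4 is the strongest of the four, and it alone lacks a hydroxyl on this part, while the dioxolane of compound 3 did not by itself separate it from compound 2. Nothing given here bears on why the number fell.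

The compounds shown leave open whether the hydroxyl or the whole hydroxymethyl is what counts, which a methyl or a methoxymethyl in its place would help to separate. An aminomethyl there would show whether a different polar group behaves like the hydroxymethyl.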